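From 3-fluorobenzyl to 3,4,5-trifluorobenzyl

The source may report more compounds than this note shows. Statements on the series, on what has been measured and on what is new or still open speak of the compounds shown alone.

Compound 1 `O=C(Nc1ccc(-c2cscn2)cc1)C1CCN(Cc2ccc(F)c(F)c2)CC1` gives > 20000 nM (a limit)
Compound 2 `O=C(Nc1ccc(-c2cscn2)cc1)C1CCCN(Cc2cccc(F)c2)C1` gives 2450 nM

Both results come from a functional assay on A-375 cells (Homo sapiens) for antiproliferative activity; a higher number here means a weaker inhibitor, a lower number a stronger inhibitor. Compound 1 stands at a limit of the assay, not at a number. For the measured compounds named here, that leaves compound 2, at 2450 nM, as the only true number available, and it is the point from which the next compound has to be judged.

That next compound is compound 3 `O=C(Nc1ccc(-c2cscn2)cc1)C1CCCN(Cc2cc(F)c(F)c(F)c2)C1`, which keeps the rest of compound 2 and differs in one place (3,4,5-trifluorophenyl in place of 3-fluorophenyl on a saturated chain carbon bound to an amine nitrogen in a ring). In words, 3,4,5-trifluorophenyl stands in place of 3-fluorophenyl on a saturated chain carbon bound to an amine nitrogen in a ring.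

Going by the values given here, no measured pair shows what a change of this kind does in this assay. The expectation therefore rests on compound 2 at 2450 nM alone. The step of a 1.2-fold higher number from compound 2 to compound 3 (0.09 log units; within the scatter) is expected to be small, possibly within the scatter, with a slight lean towards weaker inhibition. For compound 3 the estimated value is 3000 nM, with an expected range of 1000 nM to 9000 nM.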

Compound 3, half-maximal inhibitory concentration: 400 nM
The estimate for compound 3 lay 7.5-fold (0.88 log units) above the measured number; the whole stated range lies above it.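

In this assay, 3,4,5-trifluorophenyl in place of 3-fluorophenyl on a saturated chain carbon bound to an amine nitrogen in a ring gives a 6.1-fold lower number from compound 2 to compound 3 (0.79 log units; beyond the scatter). For the compounds shown here, this is the first measured pair, and it shows that this position responds to a change in the fluorine substitution of the phenyl group, here towards stronger inhibition and beyond the scatter, although the entering and leaving groups share one six-membered aromatic ring of carbon only and carry no hydrogen-bond donors or acceptors. Nothing measured here accounts for the size or direction of this step.

Going by these compounds, a single pair cannot separate the contributions of the two added fluorine atoms, so it remains open whether both are needed and how 3,5-difluorophenyl or 3,4,5-trichlorophenyl would read at this place. On these data alone, compound 1 gives > 20000 nM, which is a limit and not a number, and it differs from compound 3 in more than one place, so whether the same change holds on its core also remains open.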